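Swapping the urea amine on a dithiocarbamate triazole scaffold

A few compounds are considered here, and "the series" means these few. Any claim that something is new, unique, unknown or untested is made for them only; others in the source may bear on it.

The measured compounds:
compound 1 `CCN(C)C(=O)N1CCN(C(=S)SCc2cn(Cc3ccc(F)cc3)nn2)CC1`, 14300 nM
compound 2 `Cc1ccc(Cn2cc(CSC(=S)N3CCN(C(N)=O)CC3)nn2)cc1`, > 128000 nM

In a functional assay on EC9706 cells (Homo sapiens) for cytotoxicity, read by MTT assay, with a stated time of 72 h (on this read-out higher numbers stand for weaker inhibition and lower numbers for stronger inhibition), compound 1 gives 14300 nM. Compound 2 reaches only a limit of this assay, > 128000 nM, so no number is known for it; it sits at the limit of > 128000 nM in this assay, at which 1 of the 2 values shown sits. Among the compounds with values here, these two compounds differ in two places at once, so their values show only that compound 1 has a measured number where compound 2 has none.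

Compound 3 `CCN(C)C(=O)N1CCN(C(=S)SCc2cn(Cc3ccc(C)cc3)nn2)CC1` has not yet been measured. It differs from compound 2 in a single place: ethyl(methyl)amino in place of amino on a carbonyl carbon. That change gives compound 3 the same ethyl(methyl)carbamoyl end that compound 1 carries. Compound 3 is expected to give a real number rather than a limit, a step of an at least 4.2-fold lower number from compound 2 to compound 3 (0.63 log units; beyond the scatter) in this assay, a guess leaning on compound 1 having reached 14300 nM with that group. For compound 3 the estimate in this assay is 30000 nM, with a range from 8000 nM to 128000 nM.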

Compound 3, half-maximal inhibitory concentration: 70600 nM
For compound 3 the middle estimate is 2.4-fold (0.37 log units) below the measured one, and the stated range covers the measured number.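

Compound 3 splits the two-place gap between compound 1 and compound 2 into single changes. In this assay, replacing amino with ethyl(methyl)amino on a carbonyl carbon gives an at least 1.8-fold lower number from compound 2 to compound 3 (0.25 log units; that floor lies within the scatter), which is too small a floor to establish a real gain, and the true size of the step stays unknown because compound 2 has only a limit, not a number: the limit of > 128000 nM in this assay, at which 1 of the 3 values shown sits.

The other change, methyl in place of fluoro on an aromatic carbon, gives the first firm single-place step, a 4.9-fold higher number from compound 1 to compound 3 (0.69 log units; beyond the scatter), so with the ethyl(methyl)carbamoyl end held fixed, the group on that aromatic carbon alone shifts the read-out beyond the scatter.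

The compounds shown leave open whether chloro or methoxy on that aromatic carbon would track fluoro or methyl, since two groups cannot define a trend. Going by these compounds, it is also open whether a larger amine on the carbonyl carbon, such as diethylamino or pyrrolidine, would carry the read-out further from the limit than ethyl(methyl)amino does.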